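Piperazine nitrogen substituent change in a benzamide series

This account rests on a few compounds, and the source may have more. Where it says the series, first, only, none or still open, it means among the compounds named here.

Compound 1 `Nc1ccccc1NC(=O)c1ccc(CSC(=S)N2CCN(Cc3ccccn3)CC2)cc1` gives 23.4% in a functional assay on MGC-803 cells (Homo sapiens) for antiproliferative activity, read by CCK-8 assay, with a stated time of 72 h, tested at 2 uM (a higher number here means a stronger effect of the compound at the concentration tested, a lower number a weaker effect), and stands lowest of the three measured compounds. Compound 2 `CC1CCCCN1C(=S)SCc1ccc(C(=O)Nc2ccccc2N)cc1` gives 64.4% in this assay, and compound 3 `CN(Cc1ccncc1)C(=S)SCc1ccc(C(=O)Nc2ccccc2N)cc1` gives 38.1%; compound 1 sits nearest to compound 3, with compound 2 furthest away, both gaps beyond the scatter. Within the data shown here, the one measured step, a number 26.3 percentage points lower from compound 2 to compound 3 (beyond the scatter), is a change on the thiocarbonyl carbon and runs in the lowering direction.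

Compound 4 `Nc1ccccc1NC(=O)c1ccc(CSC(=S)N2CCN(c3ncccn3)CC2)cc1` is to be measured in this assay. It differs from compound 1 by pyrimidin-2-yl in place of (pyridin-2-yl)methyl on an amine nitrogen in a ring. Among the measured compounds shown here, this change sits on the amine nitrogen in a ring, not on the thiocarbonyl carbon, so the step from compound 2 to compound 3 does not bear on it directly; it shows only that exchanges of the group on the thiocarbonyl side move the read-out by a modest amount. For the measured compounds named here, no measured pair tests a change at the ring nitrogen, and compound 1 is already the lowest value.

With nothing to direct the change, the step is expected to be small, a number 2.6 percentage points higher from compound 1 to compound 4 (within the scatter), and not beyond the scatter. Compound 4 is therefore estimated at 26%, within a range from 10% to 45%.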

Compound 4, a percentage reported as inhibition, at one concentration (the size of the read-out at that concentration, not a potency): 28.4%
The estimate for compound 4 lay 2.4 percentage points below the measured number, and the stated range covers the measured number.
By their numbers in this assay, from the lowest: compounds 1, 4 and 3 (each within the scatter of the next, the first and the last beyond it); then compound 2.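

Among these compounds, at the amine nitrogen in a ring, the exchange of (pyridin-2-yl)methyl for pyrimidin-2-yl gives a number 5 percentage points higher from compound 1 to compound 4 (within the scatter) in this assay, the first reading at this position. The read-out therefore does not separate these two groups, even though the exchange removes the methylene link, places the aromatic ring directly on the nitrogen and adds a second ring nitrogen, so this pair gives no sign that any of these features matters at the concentration tested. Nothing measured here offers an explanation for this result.

These two groups are both six-membered aromatic rings containing nitrogen, so the pair cannot show whether a different kind of substituent on this nitrogen, such as a plain methyl, an acetyl group or a phenyl ring without ring nitrogen, would move the read-out beyond the scatter. Also open, as far as these compounds go, is whether the pair would stay this close across a range of concentrations, since a reading at a single concentration is not a potency.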